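This account rests on a few compounds, and the source may have more. Where it says the series, first, only, none or still open, it means among the compounds named here.

Working notes on the series. Compound 1 `O=C(/C=C/c1cn(-c2ccccc2)nc1-c1ccsc1)c1ccccc1` gives 1900 nM in a functional assay on MCF7 cells (Homo sapiens) for inhibition, read by sulforhodamine B assay, with a stated time of 72 h; a higher number here means a weaker inhibitor, a lower number a stronger inhibitor; compound 2 `COc1ccc(C(=O)/C=C/c2cn(-c3ccccc3)nc2-c2ccsc2)c(OC)c1` gives 9000 nM; compound 3 `O=C(/C=C/c1cn(-c2ccccc2)nc1-c1cccnc1)c1cc[nH]c1` gives 6900 nM, second highest of the three, close to compound 2 and clearly above compound 1. Compound 4 `COc1ccc(C(=O)/C=C/c2cn(-c3ccccc3)nc2-c2cccnc2)cc1OC` is still unmeasured. The change is 3,4-dimethoxyphenyl in place of 1H-pyrrol-3-yl on a carbonyl carbon. Going by the values given here, only one measured step speaks to a dimethoxyphenyl entering on a carbonyl carbon: a 4.7-fold higher number from compound 1 to compound 2 (0.68 log units; beyond the scatter), a modest rise, though there the group replaced phenyl, not 1H-pyrrol-3-yl, and carried its methoxy groups differently. A step of similar direction and modest size is therefore expected for compound 4, a 1.7-fold higher number from compound 3 to compound 4 (0.24 log units; within the scatter). Compound 4 is estimated at 12000 nM, within 4000 nM to 35000 nM.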

Compound 4, half-maximal inhibitory concentration: 1700 nM
Compound 4: the middle estimate sits 7.1-fold (0.85 log units) above what was measured, and the stated range ends above it.
By their numbers in this assay, from the lowest: compounds 4 and 1 (each within the scatter of the next); then compounds 3 and 2 (each within the scatter of the next).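

In this assay, 3,4-dimethoxyphenyl in place of 1H-pyrrol-3-yl on a carbonyl carbon gives a 4.1-fold lower number from compound 3 to compound 4 (0.61 log units; beyond the scatter), so this place accepts the bigger group and does not need the ring hydrogen-bond donor. The earlier dimethoxyphenyl step ran the other way, a 4.7-fold higher number from compound 1 to compound 2 (0.68 log units; beyond the scatter), so across these two steps, which differ in the group leaving and in the methoxy placement, a dimethoxyphenyl here has no single direction. No measurement at hand explains that difference.

Still open, as far as these compounds go, is how a dimethylamino group or a carboxylic acid on the phenyl ring at this carbonyl carbon would read.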